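Chain Lengthening on Two Cores in a Cytotoxicity Assay

A few compounds are considered here, and "the series" means these few. Any claim that something is new, unique, unknown or untested is made for them only; others in the source may bear on it.

Compound 1, `CCc1ccc(C[C@H]2COC(=O)[C@@H]2Cc2ccc(Cl)c(Cl)c2)cc1`: 16000 nM
Compound 2, `CCCCc1ccc(C[C@H]2COC(=O)[C@@H]2Cc2ccc(Cl)c(Cl)c2)cc1`: 9400 nM
Compound 3, `CCOc1ccccc1C[C@H]1COC[C@@H]1Cc1ccc(Cl)c(Cl)c1`: 29000 nM

These three compounds were measured in a functional assay on HL-60 cells (Homo sapiens) for cytotoxicity, read by WST assay, with a stated time of 48 h; on this read-out higher numbers stand for an effect only at larger amounts of compound and lower numbers for an effect already at smaller amounts. Compound 1 and compound 2 share one core; compound 3 rests on a different core, and the difference between the two cores is not broken down here. Compound 2 arises from compound 1 by ethyl in place of hydrogen on a saturated chain carbon, two bonds along the chain from an aromatic carbon, which gave a 1.7-fold lower number from compound 1 to compound 2 (0.23 log units; within the scatter). Compound 4, `CCCCOc1ccccc1C[C@H]1COC[C@@H]1Cc1ccc(Cl)c(Cl)c1`, is not yet measured; it arises from compound 3 by ethyl in place of hydrogen on a saturated chain carbon, two bonds along the chain from an oxygen on an aromatic ring. This is the same kind of change, though its place differs: in compound 2 the new chain sits two bonds along the chain from an aromatic carbon, in compound 4 two bonds along the chain from an oxygen on an aromatic ring. The earlier step, a 1.7-fold lower number from compound 1 to compound 2 (0.23 log units; within the scatter), is the basis of the expectation. For compound 4 the expected step is a 1.7-fold lower number from compound 3 to compound 4 (0.23 log units; within the scatter). In this assay compound 4 is estimated at 17000 nM, likely between 8000 nM and 40000 nM.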

Compound 4, half-maximal effective concentration: 20000 nM
Estimate against measurement, compound 4: 1.2-fold (0.07 log units) below, and the stated range covers the measured number.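

In this assay, the change from ethoxy to butoxy gives a 1.5-fold lower number from compound 3 to compound 4 (0.16 log units; within the scatter). Set beside the same lengthening on the other core, the two steps agree: the same change on two cores in this assay, a 1.7-fold lower number (0.23 log units; within the scatter) from compound 1 to compound 2 and a 1.5-fold lower number (0.16 log units; within the scatter) from compound 3 to compound 4, 1.2-fold (0.07 log units) apart, within the scatter of two such steps. The change therefore reads alike on both cores, but each step lies within the scatter, so neither shows that the added ethyl changes the number at all, and two pairs of compounds cannot establish a rule for the series.

The compounds shown leave open whether a longer chain would give a step beyond the scatter. They also leave open what an amine or a carboxylic acid at the end of the chain would do on either core.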